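The compounds below may be only part of what the source reports. "The series", "measured", "known", "first", "only" and "open" are said of these compounds alone.

Working notes on the series.

Compound 1 `COc1cc(NC(C)CCCNC(=O)NC2CCCCC2)c2ncccc2c1`, compound 2 `COc1cc(NC(C)CCCNC(=O)NNC(=O)/C=C/c2ccccc2F)c2ncccc2c1` and compound 3 `COc1cc(NC(C)CCCNC(=O)NNC(=O)NCCCCCO)c2ncccc2c1` share one core and differ only in the group carried on the terminal urea. In an ADME assay on L6 cells (Rattus norvegicus) for cytotoxicity, read by resazurin assay, with a stated time of 70 h (on this read-out higher numbers stand for weaker inhibition and lower numbers for stronger inhibition), compound 2 gives 25100 nM. In this assay compound 1 gives "not determined" (no result reported). In this assay compound 3 gives "not determined" (no result reported), so compound 3 cannot be placed against compound 2 on the numbers shown: the only figure in hand for the series is that of compound 2.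

Compound 4 `COc1cc(NC(C)CCCNC(=O)NNC(=O)Nc2ccc(C(F)(F)F)cc2)c2ncccc2c1` follows from compound 3 by one change (4-(trifluoromethyl)phenyl in place of 5-hydroxypentyl on an amide-type nitrogen). Among the measured compounds shown here, with no measured step between any two compounds in this assay, the size and direction of this change cannot be read from the data; the single value of compound 2 is the only anchor. The expectation is that compound 4 stays in the same weak region of this assay as compound 2, with a wide range on either side.

The estimate for compound 4 in this assay is 20000 nM, expected between 6000 nM and 60000 nM.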

Compound 4, half-maximal inhibitory concentration: 14900 nM
Estimate against measurement, compound 4: 1.3-fold (0.13 log units) above, and the stated range covers the measured number.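

On the carbonyl carbon, this assay now gives a first readable step: a 1.7-fold lower number from compound 2 to compound 4 (0.23 log units; within the scatter) with (4-(trifluoromethyl)phenyl)amino in place of 2-(2-fluorophenyl)ethenyl, so this pair is not told apart at this position. Among the compounds shown here, both groups carry fluorine on a phenyl ring, so the pair tests only this one exchange and gives no general reading of the position. Nothing in hand gives a measured reason for this result.

The steps from compound 1 and compound 3 to compound 2 or compound 4 cannot be read, so the 5-hydroxypentyl group remains unplaced against the 4-(trifluoromethyl)phenyl group. Also open, from the compounds shown here alone, is how a terminal amine or a carboxylic acid on a longer chain at this amide-type nitrogen would read in this assay against these two compounds.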